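Aryl replacement at the benzylidene arm, cytotoxicity working notes

The source may hold more compounds than are shown below. What is called first, only, known or untested is meant among the compounds shown, and "the series" means these compounds.

Three compounds on one shared core have been run in a functional assay on A549 cells (Homo sapiens) for cytotoxicity, read by CCK-8 assay, with a stated time of 72 h; on this read-out higher numbers stand for weaker inhibition and lower numbers for stronger inhibition. Compound 1 `C=CCn1c(=O)/c(=C\c2ccc(F)c(Br)c2)[nH]c(=O)/c1=C\c1ccccc1OC` is reported as "not active" (no number reported), and compound 2 `C=CCn1c(=O)/c(=C\c2ccc(C)cc2)[nH]c(=O)/c1=C\c1ccccc1OC` as "not active" (no number reported). For the measured compounds named here, compound 3 `C=CCn1c(=O)/c(=C\c2cc(F)ccc2C)[nH]c(=O)/c1=C\c1ccccc1OC` is the only member with a number, giving 4900 nM in this assay, so it stands alone among the measured entries; the other two give no number at all.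

Compound 4 `C=CCn1c(=O)/c(=C\c2cccc(C)c2)[nH]c(=O)/c1=C\c1ccccc1OC` differs from compound 3 by 3-methylphenyl in place of 5-fluoro-2-methylphenyl on a double-bonded chain carbon bound to an aromatic carbon. Going by the values given here, no measured pair covers this change. Because compound 2 gives "not active" (no number reported), a weakening beyond the scatter is expected, with a real chance of no number being reported. Compound 4 is estimated at 15000 nM, range 5000 nM to 50000 nM, which means an expected step of a 3.1-fold higher number from compound 3 to compound 4 (0.49 log units; beyond the scatter).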

Compound 4, half-maximal inhibitory concentration: 22700 nM
Estimate against measurement, compound 4: 1.5-fold (0.18 log units) below, and the stated range covers the measured number.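

In this assay, 3-methylphenyl in place of 5-fluoro-2-methylphenyl gives a 4.6-fold higher number from compound 3 to compound 4 (0.67 log units; beyond the scatter), the first measured size for a change at this place. Compound 4 still gives a number, 22700 nM, while compound 2 gives "not active" (no number reported), so a measurable value at this place does not depend on the fluorine. No measurement here offers an explanation for the step.

The step changes the fluorine and the methyl placement together, and the share of each stays unresolved. Going by these compounds, whether an aryl group carrying an amine or a carboxylic acid would keep a number also remains open.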